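Fluoro in place of hydrogen on the phenyl of compound 1

The compounds below may be only part of what the source reports. "The series", "measured", "known", "first", "only" and "open" are said of these compounds alone.

Compound 1 `O=C1COc2ccc(-c3cccc(NS(=O)(=O)c4ccc(F)cc4)c3)cc2N1c1ccccc1` gives > 40000 nM in a functional assay on MCF7 cells (Homo sapiens) for antiproliferative activity, read by MTT assay, with a stated time of 72 h (a higher number here means a weaker inhibitor, a lower number a stronger inhibitor), a limit rather than a number.
Compound 2 `O=C1COc2ccc(-c3cnc(Cl)c(NS(=O)(=O)c4ccc(F)cc4)c3)cc2N1C1CCCCC1` gives > 40000 nM in this assay, also a limit.
Compound 3 `Cc1ccc(N2C(=O)COc3ccc(-c4cnc(Cl)c(NS(=O)(=O)c5ccc(F)cc5)c4)cc32)cc1` gives 32600 nM in this assay.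

Compound 1 stands at the ceiling of the series: its value is a limit of this assay, not a measured number. Such limits are the common outcome here (the limit of > 40000 nM in this assay, at which 2 of the 3 values shown sit). Among the measured compounds shown here, the sole measured step, an at least 1.2-fold lower number from compound 2 to compound 3 (0.08 log units; that floor lies within the scatter), changes the group on the amide-type nitrogen and does not touch the aromatic carbon concerned in compound 4 `O=C1COc2ccc(-c3cccc(NS(=O)(=O)c4ccc(F)cc4)c3)cc2N1c1ccc(F)cc1`, which differs from compound 1 by fluoro in place of hydrogen on an aromatic carbon. For the measured compounds named here, no measured step bears on this change, so no movement beyond the scatter is expected, giving a step that the limit leaves unreadable from compound 1 to compound 4. Compound 4 is therefore estimated at 45000 nM, within 20000 nM to 100000 nM, most likely again reported only as a limit.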

Compound 4, half-maximal inhibitory concentration: > 40000 nM
Compound 4 ended at the assay's limit; the forecaster's own chance of this, stated with the estimate: 75%; the middle value is on the limit's open side.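

Compound 1 and compound 4 both stand only as limits, so the step from phenyl to 4-fluorophenyl cannot be read: the limit of > 40000 nM in this assay, at which 3 of the 4 values shown sit.

The compounds shown leave open whether fluoro in place of hydrogen here moves antiproliferative activity at all.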